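This account rests on a few compounds, and the source may have more. Where it says the series, first, only, none or still open, it means among the compounds named here.

Measured so far in an assay for inhibition of Fatty-acid amide hydrolase 1 (Rattus norvegicus), using a Dixon plot, with a stated time of 6 h; on this read-out lower numbers stand for stronger inhibition and higher numbers for weaker inhibition:
compound 1 `O=C(CCCCCCc1ccccc1)c1ncc(-c2ccc(CCl)cn2)o1` gives 24.6 nM;
compound 2 `CSC(=O)CCCCc1cnc(C(=O)CCCCCCc2ccccc2)o1` gives 1.5 nM;
compound 3 `O=C(CCCCCCc1ccccc1)c1ncc(CCCCCBr)o1` gives 6 nM.

Compound 3 stands second highest of the three numbers, between compound 2 and compound 1. The step of a 4.0-fold higher number from compound 2 to compound 3 (0.60 log units; beyond the scatter) is modest, and the step of a 4.1-fold lower number from compound 1 to compound 3 (0.61 log units; beyond the scatter) is modest in the other direction. Compound 4 `CSCCCCCc1cnc(C(=O)CCCCCCc2ccccc2)o1` differs from compound 3 by methylsulfanyl in place of bromo on a saturated chain carbon, five bonds along the chain from an aromatic carbon. Among the measured compounds shown here, no measured step exchanges bromo for methylsulfanyl directly; the nearest is a 4.0-fold higher number from compound 2 to compound 3 (0.60 log units; beyond the scatter), which swaps a chain-end sulfur group for a bromine and is modest. A step of similar size, or none beyond the scatter, is therefore expected in this assay. For compound 4 the expected value is 4 nM (range 1.5 nM to 12 nM), an expected 1.5-fold lower number from compound 3 to compound 4 (0.18 log units; within the scatter).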

Compound 4, inhibition constant: 6.1 nM
Beside the measured number, compound 4's estimate is 1.5-fold (0.18 log units) below it, within the range that was stated.
By their numbers in this assay, from the lowest: compound 2; then compounds 3 and 4 (each within the scatter of the next); then compound 1.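

In the this assay read-out, methylsulfanyl in place of bromo, on a saturated chain carbon five bonds along the chain from an aromatic carbon, gives a 1.0-fold higher number from compound 3 to compound 4 (0.01 log units; within the scatter) and so separates the two groups by nothing beyond the scatter. The carbonyl of compound 2 therefore matters even with the sulfur kept, with a 4.1-fold higher number from compound 2 to compound 4 (0.61 log units; beyond the scatter) on losing it, while the chain of compound 4 retains a 4.0-fold lower number from compound 1 to compound 4 (0.61 log units; beyond the scatter) against the ring-bearing group of compound 1. No data at hand account for these steps.

Open, on these data alone, is whether an amine, a carboxylic acid or a longer chain at this chain end would match these numbers.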